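Swapping one amide group in a weakly cytotoxic series

The compounds below may be only part of what the source reports. "The series", "measured", "known", "first", "only" and "open" are said of these compounds alone.

Measured in a functional assay on HCT-116 cells (Homo sapiens) for cytotoxicity, read by MTT assay, with a stated time of 72 h; on this read-out higher numbers stand for weaker inhibition and lower numbers for stronger inhibition
compound 1 `N[C@H]1CC[C@H](Nc2c(C(=O)NCc3ccco3)nc(Br)c3cccnc23)CC1` gives > 10000 nM
compound 2 `CN(C)c1ccc(CNC(=O)c2nc(Br)c3cccnc3c2N[C@H]2CC[C@H](N)CC2)cc1` gives "not determined" (no result reported)
compound 3 `N[C@H]1CC[C@H](Nc2c(C(=O)NCc3ccccn3)nc(Br)c3cccnc23)CC1` gives "not determined" (no result reported)

Only compound 1 has a reading, and that reading is a limit rather than a number. Compound 3 therefore has no place on the scale, and no measured step links any of these compounds.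

The unmeasured compound 4 `N[C@H]1CC[C@H](Nc2c(C(=O)NC3CCCCC3)nc(Br)c3cccnc23)CC1` keeps the shared core and changes one group. The change cyclohexyl in place of (pyridin-2-yl)methyl on an amide-type nitrogen puts cyclohexyl in place of (pyridin-2-yl)methyl on an amide-type nitrogen.

Without a number for compound 3, the size of this step cannot be read from the data. In this assay, among the measured compounds shown here, no large step toward stronger inhibition is expected for compound 4, the one guide being compound 1 with its limit > 10000 nM and nothing more. Compound 4 is expected to read about 10000 nM with 3000 nM to 30000 nM as the estimated range.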

Compound 4, half-maximal inhibitory concentration: > 10000 nM
Compound 4 gave a limit, no number; the forecaster's own chance of this, stated with the estimate: 60%; the middle value sits exactly at the limit.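

Among the compounds shown here, compound 1 and compound 4 both end at a limit rather than a number, and compound 3 has no reading, so no step among them can be read: the limit of > 10000 nM in this assay, at which 2 of the 4 values shown sit.

The compounds shown leave open whether any amide group gives a reading stronger than that limit.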